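The compounds below may be only part of what the source reports. "The series", "measured", "known", "first", "only" and "open" are said of these compounds alone.

The study concerns the shared core of compound 1 `Cn1c(-c2ccc(-c3cncnc3)cc2)nnc1C1(c2ccc(Cl)cc2)CCC1` and compound 2 `Cn1c(-c2ccc(C(N)=O)cc2C(N)=O)nnc1C1(c2ccc(Cl)cc2)CCC1`, tested for how strongly each blocks the enzyme in an assay on isolated protein for inhibition of 11-beta-hydroxysteroid dehydrogenase type 2 (Homo sapiens); on this read-out higher numbers stand for weaker inhibition and lower numbers for stronger inhibition. In this assay compound 1 gives > 4000 nM, which is a limit of the assay rather than a number. In this assay compound 2 likewise gives > 4000 nM, again a limit and not a number. Compound 2 therefore stands at the edge of what the assay can report, a position it shares with every other value shown, namely (the limit of > 4000 nM in this assay, at which 2 of the 2 values shown sit). The next compound, compound 3 `Cn1c(-c2ccc(C(N)=O)cc2Cl)nnc1C1(c2ccc(Cl)cc2)CCC1`, differs from compound 2 by chloro in place of carbamoyl on an aromatic carbon. Among the measured compounds shown here, no measured step between two compounds is available, so no step size can be read off. Because both values shown sit at the limit of > 4000 nM in this assay, at which 2 of the 2 values shown sit, compound 3 is expected to remain weak, with a step that the limit leaves unreadable from compound 2 to compound 3 expected to lie within the scatter. Compound 3 is expected to give about 5000 nM in this assay, between 1500 nM and 20000 nM, most likely once more as a limit.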

Compound 3, half-maximal inhibitory concentration: > 4000 nM
Compound 3: only a limit was reported; the forecaster's own chance of this, stated with the estimate: 70%; the middle value is on the limit's open side.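

Compound 3 gives a limit in this assay just as compound 2 does, so no step can be read for chloro in place of carbamoyl: the limit of > 4000 nM in this assay, at which 3 of the 3 values shown sit. The compounds shown leave open how strongly any of them blocks the enzyme, and whether this change matters at all.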